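The source may hold more compounds than are shown below. What is called first, only, known or untested is meant among the compounds shown, and "the series" means these compounds.

Three compounds share one core and differ only in the aromatic group attached to the sulfonyl sulfur. Compound 1 `Cc1ccc(S(=O)(=O)N(C)c2ccc3[nH]c(-c4n[nH]c5ccccc45)cc3n2)cc1` carries a 4-methylphenyl there; in a functional assay on HL-60 cells (Homo sapiens) for antiproliferative activity, read by MTT assay, with a stated time of 72 h (on this read-out higher numbers stand for weaker inhibition and lower numbers for stronger inhibition), compound 1 gives 3030 nM. Compound 2 `COc1ccc(S(=O)(=O)N(C)c2ccc3[nH]c(-c4n[nH]c5ccccc45)cc3n2)cc1OC` carries a 3,4-dimethoxyphenyl, and compound 2 gives 6320 nM. Compound 3 `COc1ccc(OC)c(S(=O)(=O)N(C)c2ccc3[nH]c(-c4n[nH]c5ccccc45)cc3n2)c1` carries a 2,5-dimethoxyphenyl, and compound 3 gives 840 nM. Compound 3 thus has the lowest number of the three: the step of a 3.6-fold lower number from compound 1 to compound 3 (0.56 log units; beyond the scatter) and the step of a 7.5-fold lower number from compound 2 to compound 3 (0.88 log units; beyond the scatter) both lowered the number, while the step of a 2.1-fold higher number from compound 1 to compound 2 (0.32 log units; beyond the scatter) raised it.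

Compound 4 `CN(c1ccc2[nH]c(-c3n[nH]c4ccccc34)cc2n1)S(=O)(=O)c1ccc(OC(F)(F)F)cc1` has not yet been measured. Its change from compound 3 is 4-(trifluoromethoxy)phenyl in place of 2,5-dimethoxyphenyl on a sulfonyl sulfur. Among the compounds with values here, two measured steps bear on this: a 3.6-fold lower number from compound 1 to compound 3 (0.56 log units; beyond the scatter) and a 7.5-fold lower number from compound 2 to compound 3 (0.88 log units; beyond the scatter), in both of which arriving at the 2,5-dimethoxyphenyl gave a lower number than either of the other two aromatic groups. Compound 4 gives up that group and instead carries a 4-(trifluoromethoxy)phenyl, a group named like the 4-methylphenyl of compound 1, so the step is expected to run the other way, moving the number back toward that of compound 1 rather than beyond it. For compound 4 a step of a 3.6-fold higher number from compound 3 to compound 4 (0.55 log units; beyond the scatter) is expected, giving an estimate of 3000 nM with a range from 1000 nM to 9000 nM.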

Compound 4, half-maximal inhibitory concentration: 1170 nM
Estimate against measurement, compound 4: 2.6-fold (0.41 log units) above, and the stated range covers the measured number.
By their numbers in this assay, from the lowest: compounds 3 and 4 (each within the scatter of the next); then compound 1; then compound 2.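

In this assay, the step of a 1.4-fold higher number from compound 3 to compound 4 (0.14 log units; within the scatter) lies within the scatter, so a second aromatic group on the sulfonyl sulfur, the 4-(trifluoromethoxy)phenyl, cannot be told apart from the 2,5-dimethoxyphenyl, and two methoxy groups are not required for a number in this range. Within the data shown here, only one place changes in the step of a 2.6-fold lower number from compound 1 to compound 4 (0.41 log units; beyond the scatter), where trifluoromethoxy replaces methyl on an aromatic carbon, and this single exchange moves the number beyond the scatter, while the step of a 5.4-fold lower number from compound 2 to compound 4 (0.73 log units; beyond the scatter) confirms that the 3,4-dimethoxyphenyl of compound 2 remains the outlier on the weak side. Nothing available here gives a measured reason for these differences.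

The compounds shown leave open how a plain phenyl, a 4-aminophenyl or a straight butyl chain on the sulfonyl sulfur would compare, and so whether an aromatic ring is needed there at all. They also leave open what would happen to the number with a hydrogen in place of the methyl on the sulfonamide nitrogen, which all four compounds share.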